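Methyl sulfoxide to methyl sulfone on a triazole core

The source may hold more compounds than are shown below. What is called first, only, known or untested is meant among the compounds shown, and "the series" means these compounds.

Measured so far:
Compound 1 `Cn1c(-c2ccccc2)nnc1[S+](C)[O-]` — in a functional assay on the whole organism for antagonist activity, with Mus musculus as the target, in the maximal electroshock model (on this read-out lower numbers stand for an effect already at smaller amounts and higher numbers for an effect only at larger amounts of compound), compound 1 gives > 100 mg/kg, a limit of the assay and not a number.
Compound 2 `Cn1c(-c2ccccc2)nnc1S(C)(=O)=O` — in this assay compound 2 gives > 200 mg/kg, again only a limit.
Compound 3 `Cn1c(-c2cccc3ccccc23)nnc1[S+](C)[O-]` — in this assay compound 3 gives > 200 mg/kg, also a limit.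

Compound 1 and compound 2 differ in one place: a group of 4 heavy atoms (1 carbon, 2 oxygen, 1 sulfur; no ring) in place of a group of 3 heavy atoms (1 carbon, 1 oxygen, 1 sulfur; no ring), on an aromatic carbon. For the measured compounds named here, because both values are limits, the step that the two limits leave unreadable from compound 1 to compound 2 cannot be read; the two values show only that neither compound reached half-maximal protection within the tested range, as the limit of > 100 mg/kg in this assay, at which 1 of the 3 values shown sits, and the limit of > 200 mg/kg in this assay, at which 2 of the 3 values shown sit, record.

Compound 4 `Cn1c(-c2cccc3ccccc23)nnc1S(C)(=O)=O` has not been measured. It carries the same kind of change on the core of compound 3 as compound 2 carries on the core of compound 1: a group of 4 heavy atoms (1 carbon, 2 oxygen, 1 sulfur; no ring) in place of a group of 3 heavy atoms (1 carbon, 1 oxygen, 1 sulfur; no ring), on an aromatic carbon. The two place descriptions agree apart from how the group borne by the ring atom two ring bonds away is named; how the two cores themselves differ is not broken down here.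

Given that the step from compound 1 to compound 2 stayed unreadable between two limits, and that compound 3 itself already sits at a limit, the estimated step that the limit leaves unreadable from compound 3 to compound 4 is expected to leave compound 4 at the limit as well. Compound 4 is expected to give about 300 mg/kg, most likely between 150 mg/kg and 1000 mg/kg.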

Compound 4, dose for half-maximal effect: > 200 mg/kg
Compound 4 gave a limit, no number; the forecaster's own chance of this, stated with the estimate: 90%; the middle value lies beyond the limit too.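

For the compounds shown here, compound 3 and compound 4 each give only a limit of the assay in this assay, not a number, so no step between them can be read. The compounds shown leave open how much the methylsulfonyl group changes the dose needed for half-maximal effect on either core, and whether any of these four compounds reaches that effect at a dose that can be given as a number.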